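A few compounds are considered here, and "the series" means these few. Any claim that something is new, unique, unknown or untested is made for them only; others in the source may bear on it.

Compound 1, with the structure `Cc1cnc(Nc2ccc(S(N)(=O)=O)cc2)nc1Nc1nc2ccccc2s1`, and compound 2, with the structure `Cc1ccc2nc(Nc3nc(Nc4ccc(S(N)(=O)=O)cc4)ncc3C)sc2c1`, were both tested in a functional assay on PC-3 cells (Homo sapiens) for antiproliferative activity, read by MTT assay, with a stated time of 48 h; a lower number here means a stronger inhibitor, a higher number a weaker inhibitor. Compound 1 in this assay returns only a limit, > 50000 nM, and that is a limit of the assay rather than a number (the limit of > 50000 nM in this assay, at which 1 of the 2 values shown sits). Compound 2 in this assay gives 2710 nM, which is the only actual number among the two results shown. Among the compounds with values here, the one measured step, an at least 18-fold lower number from compound 1 to compound 2 (1.26 log units; beyond the scatter), comes from a methyl in place of hydrogen on an aromatic carbon. Compound 3, with the structure `Cc1ccc2nc(Nc3nc(Nc4ccc(S(N)(=O)=O)cc4)ncc3F)sc2c1`, differs from compound 2 by fluoro in place of methyl on an aromatic carbon. Within the data shown here, no measured step concerns that position, so the expectation for compound 3 leans on compound 2 and its value 2710 nM alone. Compound 3 is expected to sit close to compound 2, with a step of a 1.1-fold higher number from compound 2 to compound 3 (0.04 log units; within the scatter), and an estimated value of 3000 nM in this assay, between 1000 nM and 10000 nM.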

Compound 3, half-maximal inhibitory concentration: 4960 nM
Estimate against measurement, compound 3: 1.7-fold (0.22 log units) below, within the range that was stated.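

In this assay fluoro in place of methyl on this aromatic carbon gives a 1.8-fold higher number from compound 2 to compound 3 (0.26 log units; within the scatter) and so leaves compound 2 and compound 3 indistinguishable. Within the data shown here, this is the first measured information about this position, on the six-membered aromatic ring with 2 nitrogen, and it shows that these cells do not tell methyl and fluoro apart here. Nothing in the data shown bears on why the two groups read alike.

Only these two groups are shown at this position, so it remains open whether an amine, a methoxy group, a nitrile or plain hydrogen there would read the same. On these data alone, it is also open whether fluoro would behave this way on the core of compound 1.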